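A few compounds are considered here, and "the series" means these few. Any claim that something is new, unique, unknown or untested is made for them only; others in the source may bear on it.

Two compounds have been measured in a functional assay on A549 cells (Homo sapiens) for cytotoxicity, read by sulforhodamine B assay, with a stated time of 72 h; a higher number here means a weaker inhibitor, a lower number a stronger inhibitor:

compound 1, `CCS(=O)(=O)Nc1cc(-c2ccc3ncnc(Nc4ccc(OC)c(OC)c4)c3c2)cnc1OC`, gives 5820 nM
compound 2, `CCS(=O)(=O)Nc1cc(-c2ccc3ncnc(Nc4cccc(C(=O)OC)c4)c3c2)cnc1OC`, gives 1100 nM

Compound 2 has the lowest number of the two. Among the compounds with values here, its only neighbour is compound 1, and the step between them is a 5.3-fold lower number from compound 1 to compound 2 (0.72 log units; beyond the scatter). Within the data shown here, that is the single measured step, and it shows that the group on the nitrogen on the aromatic ring moves the number over a modest range.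

Compound 3, `CCS(=O)(=O)Nc1cc(-c2ccc3ncnc(Nc4ccc(C(=O)OC)c(OC)c4)c3c2)cnc1OC`, has not yet been measured in this assay. It differs from compound 2 in one place: 3-methoxy-4-(methoxycarbonyl)phenyl in place of 3-(methoxycarbonyl)phenyl on a nitrogen on an aromatic ring. Among the measured compounds shown here, the entering group carries a methoxy, as compound 1 does, together with a methoxycarbonyl, as compound 2 does, so the one measured step pulls in both directions at once. Because the step of a 5.3-fold lower number from compound 1 to compound 2 (0.72 log units; beyond the scatter) lowered the number when methoxycarbonyl took the place of methoxy groups, and compound 3 brings a methoxy back beside a methoxycarbonyl, the step to compound 3 is expected to be a 2.3-fold higher number from compound 2 to compound 3 (0.36 log units; beyond the scatter), a moderate rise, probably beyond the scatter but well short of the full gap back to compound 1. Compound 3 is therefore estimated at 2500 nM, within a range from 800 nM to 8000 nM.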

Compound 3, half-maximal inhibitory concentration: 3350 nM
Compound 3: the middle estimate sits 1.3-fold (0.13 log units) below what was measured, within the range that was stated.
By their numbers in this assay, from the lowest: compound 2; then compounds 3 and 1 (each within the scatter of the next).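

In this assay the 3-methoxy-4-(methoxycarbonyl)phenyl group on the nitrogen gives a 3.0-fold higher number from compound 2 to compound 3 (0.48 log units; beyond the scatter) and so does not keep the lower number of compound 2, which means that carrying a methoxycarbonyl group is not enough on its own. Methoxycarbonyl in place of methoxy on an aromatic carbon gives a 1.7-fold lower number from compound 1 to compound 3 (0.24 log units; within the scatter) and leaves compounds 1 and 3 indistinguishable here, so this swap, unlike the change from compound 1 to compound 2, has no readable effect. The same kinds of group therefore give different results on this ring depending on how they are arranged, but no outside evidence accounts for this.

A plain 4-(methoxycarbonyl)phenyl group is not among the compounds shown, so it remains open whether the rise at compound 3 goes with the added methoxy or with the different placing of the methoxycarbonyl. Going by these compounds, it is also open whether a carboxylic acid or an amide in place of the methoxycarbonyl would hold or lower the number of compound 2.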